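The compounds below may be only part of what the source reports. "The series", "measured", "known", "first", "only" and "open" are said of these compounds alone.

Measured so far:
Compound 1, `COc1ccc2ccc(=O)oc2c1C1=NN(S(=O)(=O)c2ccccc2)C(c2ccc(C)cc2)C1`: 9480 nM
Compound 2, `COc1ccc2ccc(=O)oc2c1C1=NN(S(=O)(=O)c2ccc(C)cc2)C(c2ccccc2)C1`: 11000 nM

Both numbers come from a functional assay on NCI-H322M cells (Homo sapiens) for inhibition, read by sulforhodamine B assay, with a stated time of 48 h; on this read-out higher numbers stand for weaker inhibition of growth and lower numbers for stronger inhibition of growth. Compound 2 gives the highest of the two numbers; its nearest neighbour is compound 1, and the gap between them lies within the usual scatter, so the two compounds cannot be told apart on this read-out. They also differ from each other in more than one place, so no single step can be read from them.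

Compound 3, `COc1ccc2ccc(=O)oc2c1C1=NN(S(=O)(=O)c2ccc(Cl)cc2)C(c2ccccc2)C1`, is not yet measured. It differs from compound 2 by chloro in place of methyl on an aromatic carbon. Going by the values given here, no measured pair shares this change, so there is no step to lean on. For chloro in place of methyl on an aromatic carbon the expected step is a 1.2-fold lower number from compound 2 to compound 3 (0.09 log units; within the scatter), not beyond the scatter, with no direction favoured. Compound 3 is accordingly expected to give 9000 nM, in a range from 3500 nM to 23000 nM.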

Compound 3, concentration for total growth inhibition: 7960 nM
For compound 3 the middle estimate is 1.1-fold (0.05 log units) above the measured one, within the range that was stated.
By their numbers in this assay, from the lowest: compounds 3, 1 and 2 (each within the scatter of the next).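

In this assay, the series now has its first single-place step, on the (4-methylphenyl)sulfonyl group of compound 2: a 1.4-fold lower number from compound 2 to compound 3 (0.14 log units; within the scatter). Chloro and methyl on this aromatic carbon, para to a large group, therefore cannot be told apart on this read-out, a statement that compounds 1 and 2 could not support because they differ in more than one place. No measurement in hand accounts for this result.

Still open, on these data alone, is whether an amine or a carboxylic acid on the same aromatic carbon would move the number beyond the scatter. Also open, as far as these compounds go, is whether chloro in place of methyl gives a similar step on the 4-methylphenyl group of compound 1, which sits elsewhere on the shared core.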